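Cyclopropyl for tert-Butyl on the Shared Core

This account rests on a few compounds, and the source may have more. Where it says the series, first, only, none or still open, it means among the compounds named here.

Among the compounds with values here, compound 2 `CNc1nc(NCC(C)(C)C)cc(-c2ccccn2)n1` gives 73 nM in a functional assay on HEK293 cells for agonist activity at G-protein coupled receptor 39 (Homo sapiens), read by inositol phosphate accumulation (on this read-out higher numbers stand for an effect only at larger amounts of compound and lower numbers for an effect already at smaller amounts), the highest of the three numbers measured so far. Compound 1 `CNc1nc(NCc2ccc(OC(F)(F)F)cc2)cc(-c2ccccn2)n1` gives 13 nM in this assay, and compound 3 `CNc1nc(NCc2ccc(NC(C)=O)cc2F)cc(-c2ccccn2)n1` gives 1 nM; both gaps to compound 2 lie beyond the scatter. Compound 4 `CNc1nc(NCC2CC2)cc(-c2ccccn2)n1` differs from compound 2 in one place: cyclopropyl in place of tert-butyl on a saturated chain carbon bound to a nitrogen on an aromatic ring. Within the data shown here, no measured pair shows this change, and the two compounds with lower numbers differ from compound 2 in more than one place, so they offer no direct guide. The expected step is a 1.5-fold higher number from compound 2 to compound 4 (0.18 log units; within the scatter), a modest shift not clearly beyond the scatter in either direction. Compound 4 is estimated at 110 nM, with a likely range from 35 nM to 350 nM.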

Compound 4, half-maximal effective concentration: 164 nM
Beside the measured number, compound 4's estimate is 1.5-fold (0.17 log units) below it, within the range that was stated.
By their numbers in this assay, from the lowest: compound 3; then compound 1; then compound 2; then compound 4.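

Cyclopropyl in place of tert-butyl on a saturated chain carbon bound to a nitrogen on an aromatic ring gives a 2.2-fold higher number from compound 2 to compound 4 (0.35 log units; beyond the scatter) in this assay. Within the data shown here, this is the only direct reading of a change at this position, and it shows that the number responds to the group there, even with a small change from neopentyl to cyclopropylmethyl. No available evidence accounts for the size or direction of this step. On these data alone, it remains open how a cyclobutyl group, a longer chain or an amine in this place would read, and whether the same step would hold with a benzyl group elsewhere on the shared core.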